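Inverting One Chain Stereocentre Among Stereoisomers at a Limit

The compounds below may be only part of what the source reports. "The series", "measured", "known", "first", "only" and "open" are said of these compounds alone.

Three stereoisomers have been measured in an ADME assay on Colon (Mus musculus, strain C57BL/6) for metabolic stability, read by HPLC, with a stated time of 12 h (a higher number here means that the compound lasts longer, a lower number that the compound disappears faster), and each gives only a limit. Compound 1 (`O=C(O)[C@H](CO)NC(=O)[C@H]1C[C@H](O)CN1`) gives > 12 h as a limit. Compound 2 (`O=C(O)[C@@H](CO)NC(=O)[C@H]1C[C@H](O)CN1`) gives > 12 h as a limit too. Compound 3 (`O=C(N[C@H](CO)C(=O)O)[C@@H]1C[C@H](O)CN1`) gives > 12 h as a limit as well, so it stands level with the other two on the same limit (the limit of > 12 h in this assay, at which 3 of the 3 values shown sit).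

Compound 4 (`O=C(O)[C@H](CO)NC(=O)[C@@H]1C[C@H](O)CN1`) departs from compound 3 by one change (the two compounds have the same atoms and bonds and differ only in configuration as drawn: 1 of 3 stereo elements differ; a stereocentre at a saturated chain carbon is drawn R in compound 3 and S in compound 4): a stereocentre at a saturated chain carbon is drawn R in compound 3 and S in compound 4.

Among the measured compounds shown here, three measured steps bear on this: a step that the two limits leave unreadable from compound 1 to compound 2 at a chain stereocentre, a step that the two limits leave unreadable from compound 2 to compound 3 at a ring stereocentre, and a step that the two limits leave unreadable from compound 1 to compound 3 at both. None has a readable size, yet none of these configurations gave a number below the limit. No step beyond the scatter is therefore expected, and no direction can be given for the expected step (a step that the limit leaves unreadable from compound 3 to compound 4).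

Compound 4 is estimated at 14 h within an expected range from 10 h to 24 h and will most probably be reported as a limit.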

Compound 4, half-life: > 12 h
Compound 4: only a limit was reported (the forecaster's own chance of this, stated with the estimate: 90%); the middle value does not contradict the limit.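

Compound 4 stands at the same limit as compounds 1, 2 and 3, so no step from any of them to compound 4 can be read: the limit of > 12 h in this assay, at which 4 of the 4 values shown sit.

The compounds shown leave open how long each of the four stereoisomers lasts beyond that limit in this assay, and whether either stereocentre matters at all.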